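Compound 3: swapping the bromopyridine for a hydroxypyridine

This account rests on a few compounds, and the source may have more. Where it says the series, first, only, none or still open, it means among the compounds named here.

Measured so far in an ADME assay on A549 cells (Homo sapiens) for cytotoxicity, read by resazurin assay, with a stated time of 48 h; on this read-out higher numbers stand for lower toxicity in this test and lower numbers for higher toxicity in this test:
compound 1 `O=C(Nc1ccc(NCc2ccc(Br)cc2)cc1Cl)c1cc(Cl)ccc1O`: 40900 nM
compound 2 `O=C(Nc1ccc(NCc2cccc(Br)n2)cc1Cl)c1cc(Cl)ccc1O`: 92300 nM

Of these two compounds, compound 2 has the higher number at 92300 nM, which means lower toxicity in this test. Compound 3 `O=C(Nc1ccc(NCc2ccc(O)nc2)cc1Cl)c1cc(Cl)ccc1O` has not yet been measured. It keeps the core of compound 2 and changes one group, with 6-hydroxypyridin-3-yl in place of 6-bromopyridin-2-yl on a saturated chain carbon bound to a nitrogen on an aromatic ring.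

Within the data shown here, only one measured step bears on this change, and it is modest: a 2.3-fold higher number from compound 1 to compound 2 (0.35 log units; beyond the scatter). That step placed 6-bromopyridin-2-yl where compound 1 has 4-bromophenyl, so it changed the same position but involved a different swap. Neither measured compound carries the new group, which makes this weak guidance. A small upward move in this assay is therefore expected, and it may not clear the usual scatter: a 1.3-fold higher number from compound 2 to compound 3 (0.11 log units; within the scatter). Compound 3 is expected at 120000 nM, with an estimated range of 45000 nM to 300000 nM.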

Compound 3, half-maximal cytotoxic concentration: 98500 nM
Compound 3: middle estimate off by 1.2-fold (0.09 log units), on the high side; measured number inside the range.
By their numbers in this assay, from the lowest: compound 1; then compounds 2 and 3 (each within the scatter of the next).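

In this assay, the bromine and the hydroxyl group can be exchanged at this position, together with a shift of the ring's attachment from the 2-yl to the 3-yl position, without any reading that can be told apart from scatter: the step is a 1.1-fold higher number from compound 2 to compound 3 (0.03 log units; within the scatter). The gain over the 4-bromophenyl compound also appears with a second pyridine, as a 2.4-fold higher number from compound 1 to compound 3 (0.38 log units; beyond the scatter) sits alongside a 2.3-fold higher number from compound 1 to compound 2 (0.35 log units; beyond the scatter), so among these three compounds both pyridines give higher numbers than the phenyl ring, and none goes against this, although two examples are a thin basis. No measured information on these compounds explains why the pyridines differ from the phenyl ring or why the two pyridines read alike.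

On these data alone, because the substituent and the attachment point differ together between compound 2 and compound 3, the effect of each alone remains unknown, and the two could even offset each other. As far as these compounds go, it also stays open how this position would respond to a pyridine carrying an amine or a carboxylic acid, or to a longer chain between the ring and the nitrogen.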